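What One Added Group May Do to Compound 2

This account rests on a few compounds, and the source may have more. Where it says the series, first, only, none or still open, it means among the compounds named here.

In a physicochemical assay for solubility, at pH 7.4 (on this read-out higher numbers stand for higher solubility and lower numbers for lower solubility), compound 2 `O=C(/C=C/c1cccc(/C=C/C(=O)c2ccccc2)n1)NO` gives 16000 nM, within the scatter of compound 1 `CN1CCN(c2ccc(C(=O)/C=C/c3cccc(/C=C/C(=O)NO)c3)cc2)CC1` at 15000 nM, while compound 3 `CN1CCN(c2ccccc2C(=O)/C=C/c2cccc(/C=C/C(=O)NO)n2)CC1` gives 450000 nM. Compound 4 `CN1CCN(c2cccc(C(=O)/C=C/c3cccc(/C=C/C(=O)NO)n3)c2)CC1` is still unmeasured. It differs from compound 2 by 4-methylpiperazin-1-yl in place of hydrogen on an aromatic carbon, meta to a large group. For the measured compounds named here, one measured step bears on it: the same exchange at another place on that ring gives a 28-fold higher number from compound 2 to compound 3 (1.45 log units; beyond the scatter), a large step. Compound 1 also carries this group, on a different core, and its value is level with that of compound 2. A smaller step in the same direction is therefore expected in this assay, namely a 5.6-fold higher number from compound 2 to compound 4 (0.75 log units; beyond the scatter). For compound 4 the estimate is 90000 nM, with an expected range of 20000 nM to 400000 nM.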

Compound 4, solubility: 380000 nM
Estimate against measurement, compound 4: 4.2-fold (0.63 log units) below; the range from low to high includes it.
By their numbers in this assay, from the lowest: compounds 1 and 2 (each within the scatter of the next); then compounds 4 and 3 (each within the scatter of the next).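

In this assay the exchange gives a 24-fold higher number from compound 2 to compound 4 (1.38 log units; beyond the scatter) with 4-methylpiperazin-1-yl meta to a large group, so a large step is no longer tied to one place on the ring. Compound 3 and compound 4 carry the group at different places on that ring, yet their numbers lie within the scatter of each other. Between these two places, this read-out shows no separation. As far as these compounds go, whether a morpholine ring or a carboxylic acid at this place would give a step of similar size stays open. Nothing available here explains the size of the step.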